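Aryl swap on the triazole of a sulfonate series

The source may hold more compounds than are shown below. What is called first, only, known or untested is meant among the compounds shown, and "the series" means these compounds.

Compound 1, `C=C1C[C@]23C[C@@]1(O)CC[C@H]2c1ccc(OS(=O)(=O)c2ccc(C)cc2)c(C)c1[C@@H]3Cn1cc(-c2ccc(OC)cc2)nn1`, stands at the ceiling of a functional assay on SMMC-7721 cells (Homo sapiens) for cytotoxicity, read by MTT assay, with a stated time of 4 days; on this read-out higher numbers stand for weaker inhibition and lower numbers for stronger inhibition: compound 1 gives > 20000 nM, which is a limit of the assay and not a number. Compound 2, `C=C1C[C@]23C[C@@]1(O)CC[C@H]2c1cc(Br)c(O)c(C)c1[C@@H]3Cn1cc(-c2ccccc2)nn1`, gives > 20000 nM in this assay, likewise a limit. Compound 3, `C=C1C(=O)[C@]23C[C@@]1(O)CC[C@H]2c1ccc(OS(=O)(=O)c2ccc(C)cc2)c(C)c1[C@@H]3Cn1cc(-c2ccc(C)cc2)nn1`, gives 4410 nM in this assay and is the only one of the three with a numerical value. Among the compounds with values here, no pair among the three differs in one place, so the measured set holds no single step; what it shows is the limit of > 20000 nM in this assay, at which 2 of the 3 values shown sit, with compound 1 among the two values sitting there.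

Compound 4, `C=C1C[C@]23C[C@@]1(O)CC[C@H]2c1ccc(OS(=O)(=O)c2ccc(C)cc2)c(C)c1[C@@H]3Cn1cc(-c2ccc(Cl)cc2)nn1`, differs from compound 1 by chloro in place of methoxy on an aromatic carbon. Within the data shown here, the series offers no measured pair carrying this change, so its size cannot be read from the data. Compound 4 is expected to stay close to compound 1, with an at least 1.3-fold lower number from compound 1 to compound 4 (0.12 log units; that floor lies within the scatter) expected to be no larger than the usual scatter, because compound 1 gives > 20000 nM and the shared core is untouched. Compound 4 is estimated at 15000 nM, between 5000 nM and 40000 nM, with a real chance that only a limit is reported again.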

Compound 4, half-maximal inhibitory concentration: > 20000 nM
Compound 4: a limit, no number; the forecaster's own chance of this, stated with the estimate: 55%; at least 1.3-fold (0.12 log units) between middle value and limit.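

In this assay compound 4 gives > 20000 nM, again a limit and not a number. No step can be read between compound 1 and compound 4, both limits: the limit of > 20000 nM in this assay, at which 3 of the 4 values shown sit.

The compounds shown leave open what size chloro in place of methoxy has on this shared core.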